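A few compounds are considered here, and "the series" means these few. Any claim that something is new, unique, unknown or untested is made for them only; others in the source may bear on it.

Compound 3 `C#CCN(CCCCOc1ccc2ccc(=O)oc2c1)Cc1ccccc1` gives the lowest number of the three in an assay on isolated protein for inhibition of Amine oxidase [flavin-containing] B (Homo sapiens), read by fluorescence and Amplex Red, with stated times of 15 min and 20 min (on this read-out higher numbers stand for weaker inhibition and lower numbers for stronger inhibition), at 978 nM. Compound 1 `C#CCN(CCCCOc1ccc2ccc(=O)oc2c1)Cc1cccc(OC)c1` gives 2340 nM and compound 2 `C#CCN(CCCCOc1ccc2ccc(=O)oc2c1)Cc1ccc(C(C)C)cc1` gives 3500 nM in this assay. Compound 4 `C#CCN(CCCCOc1ccc2ccc(=O)oc2c1)Cc1ccc(F)c(F)c1` carries 3,4-difluorophenyl in place of phenyl on a saturated chain carbon bound to an amine nitrogen. Among the compounds with values here, two measured steps bear on it: a 2.4-fold lower number from compound 1 to compound 3 (0.38 log units; beyond the scatter) and a 3.6-fold lower number from compound 2 to compound 3 (0.55 log units; beyond the scatter), both modest and both beyond the scatter, each showing the bare phenyl giving a lower number than a substituted one. Within the data shown here, no step with a fluorine on this ring has been measured. On that basis a small rise in this assay is expected for compound 4, of the size given by a 1.5-fold higher number from compound 3 to compound 4 (0.19 log units; within the scatter). Compound 4 is therefore estimated at 1500 nM, with a range from 500 nM to 4500 nM.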

Compound 4, half-maximal inhibitory concentration: 2370 nM
Estimate against measurement, compound 4: 1.6-fold (0.20 log units) below, and the stated range covers the measured number.
By their numbers in this assay, from the lowest: compound 3; then compounds 1, 4 and 2 (each within the scatter of the next).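

Adding fluorine to this ring also gives a higher number (a 2.4-fold higher number from compound 3 to compound 4 (0.38 log units; beyond the scatter)), so compound 3, with its bare phenyl, stays below all three substituted rings shown. The 3,4-difluorophenyl of compound 4 is not separated from either other substituted ring (a 1.0-fold higher number from compound 1 to compound 4 (0.01 log units; within the scatter); a 1.5-fold lower number from compound 2 to compound 4 (0.17 log units; within the scatter)), so these compounds cannot be ordered among themselves. No measured evidence accounts for the rise.

Still open, going by these compounds, is whether a single fluorine, a hydroxyl or a nitrile on this ring would match or go below compound 3. On these data alone, the effect of replacing the benzyl group with a longer chain between ring and amine nitrogen also remains open.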